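The compounds below may be only part of what the source reports. "The series", "measured", "known", "first", "only" and "open" are said of these compounds alone.

Measured compounds:
- compound 1 `C[Se]/C(=N\C(=O)c1cc2ccccc2s1)NC(=O)c1cc2ccccc2s1`, in a functional assay on K562 cells (Homo sapiens) for cytotoxicity, read by MTT assay, with a stated time of 72 h (on this read-out lower numbers stand for stronger inhibition of growth and higher numbers for weaker inhibition of growth), compound 1 gives 32400 nM
- compound 2 `C[Se]/C(=N\C(=O)c1cccs1)NC(=O)c1cccs1`, in this assay compound 2 gives 6070 nM

Of the two compounds measured, compound 2 has the lower number; compound 1 stands clearly higher, and the gap between them lies beyond the usual scatter of this assay. Compound 2 is therefore the stronger inhibitor of growth among these two.

The next compound keeps the core of compound 2 and alters the group on the selenium. Compound 3 `O=C(/N=C(/NC(=O)c1cccs1)[Se]Cc1ccccc1)c1cccs1` differs from compound 2 in one place: phenyl in place of hydrogen on a saturated chain carbon bound to a selenium atom. Read one bond further out, the change is methyl to benzyl. Within the data shown here, no pair of measured compounds with this kind of change is available here, so the direction of the step rests on judgement alone. A change of this size at the selenium substituent is expected to move the number only modestly, if at all, with no firm reason to expect a shift beyond the scatter in either direction.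

For compound 3 the value in this assay is estimated at 5000 nM, within a range from 1500 nM to 16000 nM. This estimate corresponds to an expected step of a 1.2-fold lower number from compound 2 to compound 3 (0.08 log units; within the scatter), a change that is expected to lie near or within the scatter.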

Compound 3, concentration for 50% growth inhibition: 29500 nM
Estimate against measurement, compound 3: 5.9-fold (0.77 log units) below; the whole stated range lies below it.
By their numbers in this assay, from the lowest: compound 2; then compounds 3 and 1 (each within the scatter of the next).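

In this assay the group on the selenium turns out to matter: phenyl in place of hydrogen on a saturated chain carbon bound to a selenium atom brings a 4.9-fold higher number from compound 2 to compound 3 (0.69 log units; beyond the scatter) and so moves the number clearly in the direction of weaker inhibition of growth. Compound 1 and compound 2 both carry methyl on the selenium, so they could say nothing about this position, whereas this single step shows that the position does not tolerate every change. No measurement available here bears on why the step goes this way.

From the compounds shown here alone, it remains open whether the step belongs to the phenyl ring itself or would come with any substituent larger than methyl on the selenium, as an ethyl group or a longer chain without a ring could show. Going by these compounds, it is equally open whether a chain ending in an amine or a carboxylic acid would behave like benzyl, and whether the change from methyl to benzyl would give a step of the same direction on the core of compound 1.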